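The source may hold more compounds than are shown below. What is called first, only, known or untested is meant among the compounds shown, and "the series" means these compounds.

Measured compounds:
Compound 1 `O=C(C/C=C/c1cccc(Cl)c1)Nc1nc2ccccc2c(=O)s1`: in an assay on CHO cells for displacement of a labelled ligand from adenosine receptor A2b (Homo sapiens), read by scintillation counting, with a stated time of 75 min (on this read-out higher numbers stand for weaker inhibition and lower numbers for stronger inhibition), compound 1 gives > 1000 nM, which is a limit of the assay and not a number.
Compound 2 `COc1cccc(CCC(=O)Nc2nc3ccccc3c(=O)s2)c1`: in this assay compound 2 gives 225 nM.

Going by the values given here, compound 2 carries the only numerical value in this assay so far; the other entry is a limit. For compound 1 the result sits at the limit of > 1000 nM in this assay, at which 1 of the 2 values shown sits, so it offers no number to set against compound 2. Among the compounds with values here, no step between two measured compounds is available, and compound 1 and compound 2 differ both in the side group and in the chain, so neither change can be read on its own.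

Compound 3 `O=C(CCc1ccccc1Br)Nc1nc2ccccc2c(=O)s1` is the next candidate. Its difference from compound 2 is 2-bromophenyl in place of 3-methoxyphenyl on a saturated chain carbon, two bonds along the chain from a carbonyl carbon. Within the data shown here, compound 1, the only other compound with a halogen on the ring, gives > 1000 nM, a limit; its chain differs from that of compound 3, so it is no firm guide. In this assay a modest weakening is expected, of a size at or a little beyond the usual scatter, which is the expected step of a 2.2-fold higher number from compound 2 to compound 3 (0.35 log units; beyond the scatter). Compound 3 is estimated at 500 nM, within 150 nM to 2000 nM.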

Compound 3, inhibition constant: > 1000 nM
Compound 3 ended at the assay's limit; the forecaster's own chance of this, stated with the estimate: 25%; middle value at least 2.0-fold (0.30 log units) from the limit.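

In this assay, going by these compounds alone, replacing 3-methoxyphenyl with 2-bromophenyl on a saturated chain carbon, two bonds along the chain from a carbonyl carbon, gives the first readable single-place change, an at least 4.4-fold higher number from compound 2 to compound 3 (0.64 log units; beyond the scatter), and it lies beyond the scatter. Compound 3 gives > 1000 nM, which is a limit of the assay and not a number, so this step fixes only the smallest size the change can have. This position therefore does not treat the two substituted phenyl groups alike: 3-methoxyphenyl keeps a numerical value on this read-out and 2-bromophenyl does not, and the series now has little numerical range at its weak end: the limit of > 1000 nM in this assay, at which 2 of the 3 values shown sit.

The change replaces both the substituent and its place on the ring, so the compounds shown cannot tell whether the loss goes with the bromine, with the loss of the methoxy group, or with the substituent's place. As far as these compounds go, how an unsubstituted phenyl, an amine or carboxylic acid on the ring, or a longer chain would read at this position remains open.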